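Selenocyanate carbamates: trimming the ester alkyl chain

The source may hold more compounds than are shown below. What is called first, only, known or untested is meant among the compounds shown, and "the series" means these compounds.

Measured so far:
compound 1 `CC(C)COC(=O)Nc1ccc([Se]C#N)cc1` — 49500 nM
compound 2 `N#C[Se]c1ccc(NC(=O)OCc2ccc([N+](=O)[O-])cc2)cc1` — 32800 nM

In an ADME assay on BEAS-2B cells (Homo sapiens) for cytotoxicity, read by MTT assay, with a stated time of 72 h (on this read-out lower numbers stand for stronger inhibition of growth and higher numbers for weaker inhibition of growth), compound 1 gives 49500 nM. Compound 2 gives 32800 nM in this assay. Going by the values given here, the two numbers sit within the usual scatter of each other, so compound 1 cannot be placed apart from compound 2 on this read-out; the series so far spans no range beyond that scatter, and no pair among the measured compounds differs in a single place.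

Compound 3 `CCOC(=O)Nc1ccc([Se]C#N)cc1` is not yet measured. It differs from compound 1 by methyl in place of isopropyl on a saturated chain carbon bound to an oxygen next to a carbonyl group. Among the compounds with values here, no measured pair shows a step of this kind, so the expectation rests on the two numbers at hand. Since both measured compounds sit close together, the step of a 1.1-fold higher number from compound 1 to compound 3 (0.05 log units; within the scatter) is expected to be small, with no clear direction beyond the scatter. For compound 3 the expected value in this assay is 55000 nM, with a range from 25000 nM to 120000 nM.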

Compound 3, concentration for total growth inhibition: 46900 nM
Beside the measured number, compound 3's estimate is 1.2-fold (0.07 log units) above it; low and high end bracket the measured number.
By their numbers in this assay, from the lowest: compounds 2, 3 and 1 (each within the scatter of the next).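

In this assay, methyl in place of isopropyl on a saturated chain carbon bound to an oxygen next to a carbonyl group gives a 1.1-fold lower number from compound 1 to compound 3 (0.02 log units; within the scatter). Going by these compounds alone, this is the first single-place comparison, and it puts a direct reading on this position where the earlier compounds offered none. Isobutoxy and ethoxy cannot be told apart on this read-out, so this change gives no measurable separation. Nothing measured here bears on what lies behind this result.

From the compounds shown here alone, whether an amine, a carboxylic acid or a longer chain at this position would move the number beyond the scatter remains open. Also open, going by these compounds, is whether the same change would read alike in this assay with any other part of the core of compound 1 altered.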